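This account rests on a few compounds, and the source may have more. Where it says the series, first, only, none or still open, it means among the compounds named here.

Measured in a functional assay on HL-60 cells (Homo sapiens) for antiproliferative activity, with a stated time of 72 h; a lower number here means a stronger inhibitor, a higher number a weaker inhibitor:

- compound 1 `COC(=O)CN(C)Cc1c(OC)cc(OC)c(C(=O)/C=C/c2ccccc2Cl)c1O`: 400 nM
- compound 2 `COc1cc(OC)c(C(=O)/C=C/c2ccccc2Cl)c(O)c1CN1CCCC1`: 14200 nM

Of these two, compound 2 has the higher number, at 14200 nM, and so is the weaker inhibitor in this assay. Among the measured compounds shown here, the gap to compound 1 lies beyond the scatter, as the only measured step shows: a 36-fold higher number from compound 1 to compound 2 (1.55 log units; beyond the scatter). That step replaced ((methoxycarbonyl)methyl)(methyl)amino with pyrrolidin-1-yl on a saturated chain carbon bound to an aromatic carbon.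

Compound 3 `COc1cc(OC)c(C(=O)/C=C/c2ccccc2Cl)c(O)c1CN1CCCCC1` is altered at that same place, with piperidin-1-yl in place of pyrrolidin-1-yl on a saturated chain carbon bound to an aromatic carbon. The measured step shows that the group on this carbon can matter a great deal, but it is a guide only to sensitivity. It exchanged an open-chain group for a ring, whereas here one ring replaces another. For the measured compounds named here, no measured pair tests a change of ring size, so the data give no direction, and a step beyond the scatter is not expected. The expected step is a 1.3-fold lower number from compound 2 to compound 3 (0.11 log units; within the scatter). For compound 3 the estimated value is 11000 nM, with an expected range from 4000 nM to 30000 nM.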

Compound 3, half-maximal inhibitory concentration: 3600 nM
Compound 3: middle estimate off by 3.1-fold (0.49 log units), on the high side, outside the stated range (below it).
By their numbers in this assay, from the lowest: compound 1; then compound 3; then compound 2.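

In this assay, among the compounds shown here, the group on this saturated chain carbon bound to an aromatic carbon proves sensitive even to a change between two rings, with a 3.9-fold lower number from compound 2 to compound 3 (0.60 log units; beyond the scatter), so the earlier step from an open-chain group to a ring was not the only kind of change that moves the number here. Going to the larger ring recovers only part of the gap, however, as a 9.0-fold higher number from compound 1 to compound 3 (0.95 log units; beyond the scatter) remains, and compound 1, with ((methoxycarbonyl)methyl)(methyl)amino, keeps the lowest number of the three. Nothing available here bears on why piperidin-1-yl and pyrrolidin-1-yl differ in this way.

The compounds shown leave open whether the number keeps falling with ring size, as a single pair cannot set a trend, and a seven-membered azepan-1-yl group or a morpholin-4-yl ring, with oxygen as a second hetero atom, would extend the comparison. They also leave open which part of ((methoxycarbonyl)methyl)(methyl)amino sets compound 1 apart, a question that the corresponding carboxylic acid or a plain dimethylamino group at the same place would address.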